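The source may hold more compounds than are shown below. What is called first, only, known or untested is meant among the compounds shown, and "the series" means these compounds.

Of the compounds shown here, three have been measured so far. Compound 1 `CC(=O)Nc1ccc(-c2nc3cc([N+](=O)[O-])ccc3[nH]2)cc1` in an ADME assay on MDBK cells (Bos taurus) for cytotoxicity, read by MTT assay, with a stated time of 96 h (a lower number here means that less compound is tolerated, a higher number that more compound is tolerated), gives > 100000 nM, which is a limit of the assay rather than a number. Compound 2 `CC(=O)Nc1ccc(-c2nc3ccccc3[nH]2)cc1` in this assay gives > 100000 nM, again a limit. Between them lies (hydrogen in place of nitro on an aromatic carbon), and the step that the two limits leave unreadable from compound 1 to compound 2 cannot be read because of the limit of > 100000 nM in this assay, at which 2 of the 3 values shown sit. Within the data shown here, compound 3 `O=[N+]([O-])c1ccc(-c2nc3ccccc3[nH]2)c([N+](=O)[O-])c1` in this assay gives 20000 nM, the only number among the three. The difference between the core of compound 1 and the core of compound 3 is not broken down here. Compound 4 `O=[N+]([O-])c1ccccc1-c1nc2ccccc2[nH]1` is not yet measured. It differs from compound 3 by hydrogen in place of nitro on an aromatic carbon, the same kind of change as from compound 1 to compound 2 but not the same: there the place was on a ring that is part of a fused or bridged system of two rings, meta to a fused ring and para to a fused ring; here it is on a six-membered aromatic ring of carbon only, meta to a nitro group and para to a group of 9 heavy atoms. The earlier step is unreadable, so no size can be taken from it. Compound 4 is expected to be tolerated more than compound 3, an estimated step of a 3.0-fold higher number from compound 3 to compound 4 (0.48 log units; beyond the scatter). The expectation rests on compound 2, which in this assay sits at a limit, > 100000 nM. For compound 4 the estimate in this assay is 60000 nM, expected to fall between 25000 nM and 150000 nM.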

Compound 4, half-maximal cytotoxic concentration: > 100000 nM
Compound 4: only a limit was reported; the forecaster's own chance of this, stated with the estimate: 45%; middle value at least 1.6-fold (0.22 log units) away from the limit.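

In this assay, hydrogen in place of nitro on an aromatic carbon of the six-membered aromatic ring of carbon only gives an at least 5.0-fold higher number from compound 3 to compound 4 (0.69 log units; beyond the scatter), so on this core the change is readable and raises the tolerated concentration. Going by these compounds, the full size of that step stays open, as compound 4 gives > 100000 nM, which is a limit and not a number. Whether the effect carries over from one core to the other is not shown, because the same kind of change from compound 1 to compound 2 cannot be read, and both steps run into one ceiling: the limit of > 100000 nM in this assay, at which 3 of the 4 values shown sit.

The compounds shown leave open whether this change would give a readable step on another core whose nitro compound stands clear of that limit, as only compound 3 does here. They also leave open how an amine or a carboxylic acid at the place of the nitro group would fare in this assay.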